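Acetoxy ester in place of the diol side chain

The compounds below may be only part of what the source reports. "The series", "measured", "known", "first", "only" and "open" are said of these compounds alone.

For the measured compounds named here, compound 2 `CC(C)(CC(=O)N[C@@H]1CCc2ccccc2N(Cc2ccc(-c3ccccc3-c3nn[nH]n3)cc2)C1=O)NC[C@H](O)CO` stands lowest of the two numbers measured so far: in a functional assay (Pituitary gland cell) with Rattus norvegicus as the target (a higher number here means that more compound is needed for the effect, a lower number that less compound is needed), compound 2 gives 10 nM, while compound 1 `CC(C)(CC(=O)N[C@@H]1CCc2ccccc2N(Cc2ccc(-c3ccccc3-c3nn[nH]n3)cc2)C1=O)NCCO` gives 30 nM. Going by the values given here, the only step at hand, a 3.0-fold lower number from compound 1 to compound 2 (0.48 log units; beyond the scatter), came with the added hydroxymethyl. Compound 3 `CC(=O)O[C@@H](C)CNC(C)(C)CC(=O)N[C@@H]1CCc2ccccc2N(Cc2ccc(-c3ccccc3-c3nn[nH]n3)cc2)C1=O` goes the other way: 1-acetoxyethyl in place of 1,2-dihydroxyethyl on a saturated chain carbon bound to an amine nitrogen. Both hydroxyls of compound 2 are removed, and the new group carries no donors. The gain seen in a 3.0-fold lower number from compound 1 to compound 2 (0.48 log units; beyond the scatter) is therefore expected to be lost, with a modest rise expected, a 4.0-fold higher number from compound 2 to compound 3 (0.60 log units; beyond the scatter). Compound 3 is estimated at 40 nM, within 15 nM to 120 nM.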

Compound 3, concentration for half-maximal effect: 200 nM
Compound 3: middle estimate off by 5.0-fold (0.70 log units), on the low side; measured number outside the range, above it.
By their numbers in this assay, from the lowest: compound 2; then compound 1; then compound 3.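

Replacing 1,2-dihydroxyethyl with 1-acetoxyethyl on the saturated chain carbon bound to an amine nitrogen has a large effect, a 20-fold higher number from compound 2 to compound 3 (1.30 log units; beyond the scatter). This is more than a return to the level without the added hydroxymethyl, as the number also ends past that level, a 6.7-fold higher number from compound 1 to compound 3 (0.82 log units; beyond the scatter). Nothing at hand accounts for the size of this step.

The compounds shown leave open whether the rise follows the loss of the hydroxyls or the entry of the acetyl. A 2-hydroxypropyl or 2-methoxypropyl group on that amine nitrogen would separate the two.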